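This account rests on a few compounds, and the source may have more. Where it says the series, first, only, none or still open, it means among the compounds named here.

Compound 2, whose structure is `CCCCCCCC/C=C\CCCCCCC(=O)c1nc2cccnc2o1`, gives the lowest of the two numbers seen so far in an assay on isolated protein for inhibition of Fatty-acid amide hydrolase 1 (Homo sapiens); on this read-out higher numbers stand for weaker inhibition and lower numbers for stronger inhibition: compound 2 gives 11 nM. Its nearest neighbour is compound 1, with the structure `CCCCCCCC/C=C\CCCCCCC(=O)c1nnn(C)n1`, and in this assay compound 1 gives 65 nM. Within the data shown here, the one measured step, a 5.9-fold lower number from compound 1 to compound 2 (0.77 log units; beyond the scatter), shows that exchanging the aromatic group on the carbonyl carbon can move this assay by a modest amount beyond the scatter.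

Compound 3, with the structure `CCCCCCCC/C=C\CCCCCCC(=O)c1ccncn1`, is not yet measured. It differs from compound 2 in one place: a group of 6 heavy atoms (4 carbon, 2 nitrogen; one six-membered aromatic ring with 2 hetero atoms) in place of a group of 9 heavy atoms (6 carbon, 2 nitrogen, 1 oxygen; one five-membered aromatic ring with 2 hetero atoms, one six-membered aromatic ring with 1 hetero atom), on a carbonyl carbon. The step from compound 1 to compound 2 is the only one that bears on this, since it also swaps the aromatic group on the carbonyl carbon, but it does not contain the pyrimidin-4-yl group itself, so the direction rests on the observation that the larger group in compound 2 gave the lower number. Compound 3 is therefore expected to show a modest rise, a 5.5-fold higher number from compound 2 to compound 3 (0.74 log units; beyond the scatter), in this assay. The estimate for compound 3 is 60 nM, within a range from 15 nM to 300 nM.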

Compound 3, inhibition constant: 110 nM
Beside the measured number, compound 3's estimate is 1.8-fold (0.26 log units) below it; measured number inside the range.
By their numbers in this assay, from the lowest: compound 2; then compounds 1 and 3 (each within the scatter of the next).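

Swapping the two-ring group of compound 2 for pyrimidin-4-yl on the carbonyl carbon gives a 10-fold higher number from compound 2 to compound 3 (1.00 log units; beyond the scatter), the largest step yet in this assay. The two single-ring groups, 2-methyl-2H-tetrazol-5-yl and pyrimidin-4-yl, cannot be told apart (a 1.7-fold higher number from compound 1 to compound 3 (0.23 log units; within the scatter)), so among these three compounds only the two-ring group of compound 2 stands apart, even though the single rings carry different hetero atoms. Nothing measured here explains why this group gives the lowest number.

From the compounds shown here alone, it remains open whether that low number belongs to the presence of a second ring or to the particular hetero atoms of compound 2. An oxazol-2-yl group and a benzoxazol-2-yl group on the same carbonyl carbon would help separate these two readings, since each keeps only part of the two-ring group.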